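The compounds below may be only part of what the source reports. "The series", "measured", "known", "first", "only" and "open" are said of these compounds alone.

Measured so far:
Compound 1 `COC(=O)c1sc2ncnc(Nc3cc(C)cn(C)c3=O)c2c1C`. In an assay on isolated protein for inhibition of MAP kinase-interacting serine/threonine-protein kinase 1 (Homo sapiens), read by ADP-Glo, with a stated time of 10 min (on this read-out higher numbers stand for weaker inhibition and lower numbers for stronger inhibition), compound 1 gives > 10000 nM, which is a limit of the assay and not a number.
Compound 2 `CCNC(=O)c1sc2ncnc(Nc3cc(C)cn(C)c3=O)c2c1C`. In this assay compound 2 gives > 10000 nM, again a limit of the assay.
Compound 3 `COCCNC(=O)c1sc2ncnc(Nc3cc(C)cn(C)c3=O)c2c1C`. In this assay compound 3 gives 5400 nM.

Going by the values given here, compound 3 thus stands as the only compound with a read number; the other two sit at the limit of > 10000 nM in this assay, at which 2 of the 3 values shown sit. The step that the two limits leave unreadable from compound 1 to compound 2 cannot be sized. The steps of an at least 1.8-fold lower number from compound 1 to compound 3 (0.26 log units; that floor lies within the scatter) and an at least 1.8-fold lower number from compound 2 to compound 3 (0.26 log units; that floor lies within the scatter) are floors only, and both floors lie within the scatter, so no change beyond scatter is established for any pair.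

Compound 4 `COCCCNC(=O)c1sc2ncnc(Nc3cc(C)cn(C)c3=O)c2c1C` differs from compound 3 by methoxymethyl in place of methoxy on a saturated chain carbon, two bonds along the chain from an amide-type nitrogen. Among the compounds with values here, no measured step lengthens the chain beyond the methoxy; the two steps into compound 3 only set floors that sit within the scatter. The expectation is therefore no step beyond the scatter, a 1.1-fold lower number from compound 3 to compound 4 (0.03 log units; within the scatter). For compound 4 the estimated value in this assay is 5000 nM, with a range from 1800 nM to 14000 nM.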

Compound 4, inhibition constant: 5000 nM
Beside the measured number, compound 4's estimate shows no gap at the digits printed, and the stated range covers the measured number.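

In this assay, (3-methoxypropyl)amino in place of (2-methoxyethyl)amino gives a second read number on this amide chain (a 1.1-fold lower number from compound 3 to compound 4 (0.03 log units; within the scatter)), so these two chain lengths cannot be told apart. Set against the compounds without a read number, compound 4 gives two further steps (an at least 2.0-fold lower number from compound 2 to compound 4 (0.30 log units; that floor lies within the scatter)) and (an at least 2.0-fold lower number from compound 1 to compound 4 (0.30 log units; that floor lies within the scatter)), so no gain beyond the scatter is established for either methoxy-bearing chain. These steps remain floors because compound 1 and compound 2 give no number: (the limit of > 10000 nM in this assay, at which 2 of the 4 values shown sit).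

As far as these compounds go, whether any change at this place gives a step beyond the scatter stays open, for instance a longer chain, or an amine or a carboxylic acid in place of the terminal methoxy. Going by these compounds alone, how much the chain's ether oxygen contributes also stays open, since the steps that bear on it are floors only.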